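From 2-methylbenzyl to 4-(tert-butyl)benzyl

A few compounds are considered here, and "the series" means these few. Any claim that something is new, unique, unknown or untested is made for them only; others in the source may bear on it.

In a functional assay on HCT-116 cells (Homo sapiens) for inhibition, read by MTT assay, with a stated time of 72 h (a lower number here means a stronger inhibitor, a higher number a weaker inhibitor), compound 1 (`O=C1/C(=C\c2ccccc2)c2c(ncn2COCc2ccccc2)CCN1Cc1ccc(-c2ccccc2)cc1`) gives 14000 nM and compound 2 (`COc1ccc(CN2CCc3ncn(COCc4ccccc4)c3/C(=C/c3ccccc3)C2=O)cc1`) gives 31100 nM while compound 3 (`Cc1ccccc1CN1CCc2ncn(COCc3ccccc3)c2/C(=C/c2ccccc2)C1=O`) gives 24700 nM on the same scale. Compound 3 therefore lies within the usual scatter of both other compounds, and these values do not rank it against either one.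

Compound 4 (`CC(C)(C)c1ccc(CN2CCc3ncn(COCc4ccccc4)c3/C(=C/c3ccccc3)C2=O)cc1`) keeps the shared core and carries 4-(tert-butyl)phenyl in place of 2-methylphenyl on a saturated chain carbon bound to an amide-type nitrogen in a ring with nothing else altered. Among the measured compounds shown here, no measured compound carries this group, so the guidance is indirect.

Changes at this same place have so far moved the number little. There is a 1.8-fold higher number from compound 1 to compound 3 (0.25 log units; within the scatter) and there is a 1.3-fold lower number from compound 2 to compound 3 (0.10 log units; within the scatter) and both stay within the scatter. Only a 2.2-fold higher number from compound 1 to compound 2 (0.35 log units; beyond the scatter) goes beyond it, and that step is modest.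

A step beyond the scatter is therefore not expected in this assay for this change. The expected step is a 1.1-fold lower number from compound 3 to compound 4 (0.05 log units; within the scatter) according to this estimate. For compound 4 the estimated value is 22000 nM with an expected range from 11000 nM to 40000 nM overall.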

Compound 4, half-maximal inhibitory concentration: 8460 nM
Compound 4: middle estimate off by 2.6-fold (0.42 log units), on the high side; the whole stated range lies above it.
By their numbers in this assay, from the lowest: compounds 4, 1, 3 and 2 (each within the scatter of the next, the first and the last beyond it).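

In this assay, this position on a saturated chain carbon bound to an amide-type nitrogen in a ring can move the number beyond the scatter, which the two earlier changes of the whole group here did not do: the change from 2-methylphenyl to 4-(tert-butyl)phenyl gives a 2.9-fold lower number from compound 3 to compound 4 (0.47 log units; beyond the scatter), a modest step. Swapping only the group on the aromatic carbon, tert-butyl in place of methoxy, gives a 3.7-fold lower number from compound 2 to compound 4 (0.57 log units; beyond the scatter), the largest step among these compounds and also modest. Tert-butyl in place of phenyl gives a 1.7-fold lower number from compound 1 to compound 4 (0.22 log units; within the scatter), which stays within the scatter, so these values do not rank compound 4 against compound 1, and the gain seen against compound 2 and compound 3 does not extend to compound 1.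

No measurement is available that explains why these steps have the sizes they do. It also remains open how the number would respond to an amine or a carboxylic acid in place of tert-butyl on the aromatic carbon, since every group shown there is either carbon-only or methoxy.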